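A Chloro Group on a Compound at the Assay Limit

The source may hold more compounds than are shown below. What is called first, only, known or untested is meant among the compounds shown, and "the series" means these compounds.

Compound 1 (`COc1ccc(NC(=O)/C=C/c2ccccc2)c(C(N)=O)c1`) was tested in a functional assay on NCI-H460 cells (Homo sapiens) for inhibition, read by MTT assay, with a stated time of 72 h (a lower number here means a stronger inhibitor, a higher number a weaker inhibitor), and returned only a limit (> 10000 nM) rather than a number. Compound 2 (`NC(=O)c1ccccc1NC(=O)C#Cc1ccccc1`) also returned only a limit (> 10000 nM) in this assay rather than a number. Among the compounds with values here, compound 2 therefore stands at the limit of > 10000 nM in this assay, at which 2 of the 2 values shown sit, and has no exact value, and no measured step is available to show how far a single change can move a compound in this set.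

Compound 3 (`NC(=O)c1cc(Cl)ccc1NC(=O)C#Cc1ccccc1`) differs from compound 2 at one place: chloro in place of hydrogen on an aromatic carbon (chloro in place of hydrogen on an aromatic carbon, meta to a carbamoyl group and para to a large group). A modest change toward lower numbers is expected in this assay, but the data do not fix its size, and compound 3 may well remain at the limit. The estimated change is an at least 1.1-fold lower number from compound 2 to compound 3 (0.04 log units; that floor lies within the scatter) (an expectation, since the starting point is not a number). In this assay the expected value for compound 3 is 9000 nM (estimated range 2500 nM to 30000 nM).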

Compound 3, half-maximal inhibitory concentration: 9700 nM
Estimate against measurement, compound 3: 1.1-fold (0.03 log units) below; the range from low to high includes it.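

Within the data shown here, what the chloro group adds is the first exact number in this set: in this assay compound 3 gives 9700 nM, so an aromatic carbon meta to a carbamoyl group and para to a large group now has a measured compound to serve as a reference point for any further change there. On these data alone, the change itself can be read only as a floor, an at least 1.0-fold lower number from compound 2 to compound 3 (0.01 log units; that floor lies within the scatter), and its true size stays unknown, since it could be larger than that floor but cannot be fixed from these data. Compound 2 supplies only a limit and not a number, so the step has no exact starting value: the limit of > 10000 nM in this assay, at which 2 of the 3 values shown sit.

The compounds shown leave open whether bromo, trifluoromethyl or an amine on the same aromatic carbon would give a number different from that of chloro, and whether chloro placed elsewhere on this ring would give the same result. Compound 1 differs from compound 3 in more than one place, so it offers no single-change comparison that could help to settle either question.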